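Butylamino addition on the quinone core: next analogue

This account rests on a few compounds, and the source may have more. Where it says the series, first, only, none or still open, it means among the compounds named here.

Compound 3 `CC(C)(C)C1=CC(=O)C=CC1=O` gives 95000 nM in an ADME assay on HaCaT cells (Homo sapiens) for cytotoxicity, read by MTT assay, with a stated time of 72 h; a lower number here means a stronger inhibitor, a higher number a weaker inhibitor. Compound 1 `CCCCNC1=CC(=O)C=C(C(C)(C)C)C1=O` carries butylamino in place of hydrogen on a double-bonded ring carbon and gives 11000 nM in this assay; the change is an 8.6-fold lower number from compound 3 to compound 1 (0.94 log units; beyond the scatter). Compound 2 `CC1=CCC[C@H]2[C@](C)(CC3=CC(=O)C=CC3=O)[C@@H](C)CC[C@]12C` gives 37000 nM in this assay, a number that sits between those of compound 3 and compound 1. How the cores of compound 2 and compound 3 differ is not broken down here. Compound 4 `CCCCNC1=CC(=O)C=C(C[C@]2(C)[C@@H](C)CC[C@]3(C)C(C)=CCC[C@@H]23)C1=O` carries butylamino in place of hydrogen on a double-bonded ring carbon relative to compound 2; the surroundings differ in that the ring atom two ring bonds away bears a large group rather than a tert-butyl group (4 heavy atoms), so this is the same kind of change, not the same change. Given the single earlier step of this kind, an 8.6-fold lower number from compound 3 to compound 1 (0.94 log units; beyond the scatter), compound 4 is expected in this assay to show a 7.4-fold lower number from compound 2 to compound 4 (0.87 log units; beyond the scatter). Compound 4 is therefore estimated at 5000 nM, expected within 1800 nM to 15000 nM.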

Compound 4, half-maximal inhibitory concentration: 16000 nM
The estimate for compound 4 lay 3.2-fold (0.51 log units) below the measured number; measured number above the stated range.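

In this assay, butylamino in place of hydrogen on a double-bonded ring carbon again gives a lower number, with a 2.3-fold lower number from compound 2 to compound 4 (0.36 log units; beyond the scatter), so the direction of the change holds on both cores. The size of the step does not carry over from one core to the other: the same change on two cores in this assay, an 8.6-fold lower number (0.94 log units; beyond the scatter) from compound 3 to compound 1 and a 2.3-fold lower number (0.36 log units; beyond the scatter) from compound 2 to compound 4, 3.7-fold (0.57 log units) apart, beyond the scatter of two such steps

These two pairs show only that the direction is shared; they do not show what sets the size of the step or how the change would behave on any further core.

Still open, on these data alone, is whether another amine on the same ring carbon, such as morpholino or the longer octylamino, would give a lower number on either core. Also open, as far as these compounds go, is whether a hydroxyl group there would do the same.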